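Benzoyl for Cyano at the Triazole Aryl Ring

The source may hold more compounds than are shown below. What is called first, only, known or untested is meant among the compounds shown, and "the series" means these compounds.

Among the measured compounds shown here, compound 1, `C=CCc1ccc(OCc2cn(-c3ccc(C#N)cc3)nn2)c(O)c1`, is one of two compounds measured in a functional assay on MIA PaCa-2 cells (Homo sapiens) for inhibition, read by MTT assay, with a stated time of 72 h, tested at 30 uM (on this read-out lower numbers stand for less inhibition of growth and higher numbers for more inhibition of growth at the one concentration tested), where compound 1 gives 39.3%. Its nearest comparator is compound 2, `C=CCc1ccc(OCc2cn(-c3cccc(C#N)c3)nn2)c(O)c1`, which in this assay gives 26.6%; the change of a number 12.7 percentage points lower from compound 1 to compound 2 (beyond the scatter) stands beyond the scatter and is modest in size, so compound 1 stands highest of the two numbers. Compound 3, `C=CCc1ccc(OCc2cn(-c3ccc(C(=O)c4ccccc4)cc3)nn2)c(O)c1`, differs from compound 1 in that (benzoyl in place of cyano on an aromatic carbon). For the measured compounds named here, the only measured step, from compound 1 to compound 2, moves the cyano group to another position on the ring and does not exchange it for another group; nothing measured tells how a much larger group at the same position behaves, so that step bears on the present one only weakly. The author therefore expects a step of a number 0.7 percentage points higher from compound 1 to compound 3 (within the scatter) in this assay, which is no change beyond the scatter in either direction. The estimate for compound 3 is 40%, with a range from 15% to 65% that reflects how little the measured data constrain this exchange.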

Compound 3, percent growth inhibition at one concentration: 40.1%
The estimate for compound 3 lay 0.1 percentage points below the measured number; low and high end bracket the measured number.
By their numbers in this assay, from the lowest: compound 2; then compounds 1 and 3 (each within the scatter of the next).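

Replacing the cyano group with benzoyl, which brings 8 heavy atoms in place of 2 and adds a six-membered aromatic ring, gives a number 0.8 percentage points higher from compound 1 to compound 3 (within the scatter) in this assay, so the read-out does not separate this pair. The earlier step, a number 12.7 percentage points lower from compound 1 to compound 2 (beyond the scatter), concerned only where the cyano group sits on the ring, whereas the new step shows that, for this one pair, the group itself can be exchanged for a much larger one with the growth inhibition remaining within the scatter. No evidence at hand gives a reason for this result.

The compounds shown leave open whether other groups at this place, such as an amine or a carboxylic acid, would also read within the scatter of compound 1. They also leave open how benzoyl would behave at the ring position that the cyano group occupies in compound 2, and whether the pair would stay level at concentrations other than the one tested.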